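The source may hold more compounds than are shown below. What is called first, only, known or untested is meant among the compounds shown, and "the series" means these compounds.

In a physicochemical assay for metabolic stability, read by HPLC, in phosphate buffer, at pH 7.4 (a higher number here means that the compound lasts longer, a lower number that the compound disappears faster), compound 2 `COC(=O)c1ccc(/N=N/N(C)C(=O)CCc2cccc(O)c2)cc1` gives 94.7 h, which lies within the scatter of both compound 1 `CN(/N=N/c1ccc(C#N)cc1)C(=O)CCc1ccc(O)cc1` at 76 h and compound 3 `CN(/N=N/c1ccc(C(N)=O)cc1)C(=O)CCCCc1ccc(O)cc1` at 182 h. Among the compounds with values here, no two measured compounds differ in only one place, so the series offers no direct reading of the change to compound 4 `COC(=O)c1ccc(/N=N/N(C)C(=O)CCc2ccc(O)cc2)cc1`. Compound 4 has the same atoms as compound 2, joined differently: 4-hydroxyphenyl in place of 3-hydroxyphenyl on a saturated chain carbon, two bonds along the chain from a carbonyl carbon. Compound 1 also carries a 4-hydroxyphenyl group and gives 76 h, so no step beyond the scatter is expected in this assay, in either direction. The expected change is a 1.1-fold lower number from compound 2 to compound 4 (0.02 log units; within the scatter). The estimated half-life for compound 4 is 90 h, with an expected range of 45 h to 180 h.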

Compound 4, half-life: 102 h
The estimate for compound 4 lay 1.1-fold (0.05 log units) below the measured number; the range from low to high includes it.
By their numbers in this assay, from the lowest: compounds 1, 2, 4 and 3 (each within the scatter of the next, the first and the last beyond it).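

In this assay, within the data shown here, 4-hydroxyphenyl in place of 3-hydroxyphenyl on a saturated chain carbon gives a 1.1-fold higher number from compound 2 to compound 4 (0.03 log units; within the scatter), the first direct reading at this place. Methoxycarbonyl in place of cyano on an aromatic carbon gives a 1.3-fold higher number from compound 1 to compound 4 (0.13 log units; within the scatter), so neither single change separates the compounds beyond the scatter. Nothing available bears on the origin of these results.

Steps to compound 3 cannot be read, as it differs from the others in more than one place. From the compounds shown here alone, whether an amine or a carboxylic acid in place of the hydroxy group would step beyond the scatter remains open.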